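A few compounds are considered here, and "the series" means these few. Any claim that something is new, unique, unknown or untested is made for them only; others in the source may bear on it.

Compound 1 `CC(C)C(c1ccc(-c2ccc3cccc(F)c3c2)[nH]c1=O)C1C(=O)NC(=O)N1C`: 13600 nM
Compound 2 `CC(C)C(c1ccc(-c2ccc3cccc(F)c3c2)[nH]c1=O)C1SC(=O)NC1=O`: 11300 nM
Compound 3 `O=C1NC(=O)/C(=C/C(Cc2ccccc2)c2ccc(-c3ccc4cccc(F)c4c3)[nH]c2=O)O1`: 900 nM

These three compounds share a core and differ in the group carried on the saturated chain carbon bound to an aromatic carbon and a saturated chain carbon. In a physicochemical assay for solubility, measured as kinetic solubility, at pH 2 (a lower number here means a less soluble compound, a higher number a more soluble compound), compound 2 stands second highest of the three numbers; compound 1 sits closest to it, and compound 3 lies far below it. Within the data shown here, the one step between neighbours, a 1.2-fold lower number from compound 1 to compound 2 (0.08 log units; within the scatter), shows that exchanging one five-membered ring for another at this position did not move the number beyond the scatter.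

Compound 4 `CC(C)C(/C=C1/C(=O)NC(=O)N1C)c1ccc(-c2ccc3cccc(F)c3c2)[nH]c1=O` has not yet been measured in this assay. Relative to compound 2 it carries a group of 9 heavy atoms (5 carbon, 2 nitrogen, 2 oxygen; one five-membered non-aromatic ring with 2 hetero atoms) in place of a group of 7 heavy atoms (3 carbon, 1 nitrogen, 2 oxygen, 1 sulfur; one five-membered non-aromatic ring with 2 hetero atoms), on a saturated chain carbon bound to an aromatic carbon and a saturated chain carbon. The change adds a double bond outside the rings, so the new ring no longer hangs from a saturated carbon but is joined through an unsaturated link. Compound 3 also carries its ring through such a link and gives 900 nM, a much lower number than compound 2, though compound 3 differs from compound 2 in a second place as well, so no clean step can be read from it. A decrease beyond the scatter is therefore expected, smaller than the gap to compound 3: the step of a 2.5-fold lower number from compound 2 to compound 4 (0.40 log units; beyond the scatter) is the estimate. Compound 4 is expected to give about 4500 nM, within a range from 1500 nM to 13000 nM.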

Compound 4, solubility: 8300 nM
Beside the measured number, compound 4's estimate is 1.8-fold (0.27 log units) below it, and the stated range covers the measured number.
By their numbers in this assay, from the lowest: compound 3; then compounds 4, 2 and 1 (each within the scatter of the next).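

In this assay the two new steps are a 1.4-fold lower number from compound 2 to compound 4 (0.13 log units; within the scatter) and a 1.6-fold lower number from compound 1 to compound 4 (0.21 log units; within the scatter) and so neither can be told apart from repeated measurement. Until now, the only ring joined through a double bond was in compound 3, which left open whether such a link could go with a number close to those of compounds 1 and 2. Compound 4 shows that it can at this position, while compound 3 remains the one case against this picture, and its second difference, the benzyl group in place of the propan-2-yl group, prevents its value from being tied to the link; no measurement bears on why the numbers of compounds 1, 2 and 4 lie so close together.

What the compounds leave open is whether the benzyl group or the ring and its link accounts for the value of compound 3. From the compounds shown here alone, it is also open whether a group without a five-membered ring, such as a carboxylic acid or an amine, would stay within the scatter of compounds 1, 2 and 4 at this position.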